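Compound 3: an aryl swap starting from a limit

This account rests on a few compounds, and the source may have more. Where it says the series, first, only, none or still open, it means among the compounds named here.

- Compound 1 `CC(=O)N[C@@H]1CCN(c2cc(C)nn3c(-c4ccc(C(F)(F)F)cc4)c(C)nc23)C1` gives > 95% (a limit)
- Compound 2 `CC(=O)N[C@@H]1CCN(c2cc(C)nn3c(-c4ccc(C#N)cc4)c(C)nc23)C1` gives > 95% (a limit)

In an ADME assay on microsomes from liver (Mus musculus) for metabolic stability, read by LC-MS, with NADPH named in the record, with a stated time of 60 min, tested at 1 uM, in the absence of a further agent (a higher number here means that more of the compound is left, a lower number that less of the compound is left), compound 2 gives > 95%, which is a limit and not a number. Compound 3 `COc1cc(-c2c(C)nc3c(N4CC[C@@H](NC(C)=O)C4)cc(C)nn23)ccc1F` keeps the shared core but carries 4-fluoro-3-methoxyphenyl in place of 4-cyanophenyl on an aromatic carbon of that core. For the measured compounds named here, only one measured step bears on this change, a step that the two limits leave unreadable from compound 1 to compound 2, a swap on the same phenyl ring. Both measured compounds sit at one limit (the limit of > 95% in this assay, at which 2 of the 2 values shown sit), so no size can be carried over from that step. Compound 2 offers a limit rather than a number > 95%, so any readable change is expected to be downward. The expected step in this assay is a moderate fall a number at least 13 percentage points lower from compound 2 to compound 3 (beyond the scatter), although another result at the limit remains possible. For compound 3 the estimated value is 82%, with an expected range from 55% to 98%.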

Compound 3, percent of the compound remaining: > 95%
Compound 3 was reported as a limit; the forecaster's own chance of this, stated with the estimate: 40%; at least 13 percentage points between middle value and limit.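

In this assay compound 3 gives > 95%, which is a limit and not a number. Its steps from compound 1 and compound 2 cannot be read, since all three compounds sit at the same limit: the limit of > 95% in this assay, at which 3 of the 3 values shown sit.

The compounds shown leave open whether 4-(trifluoromethyl)phenyl, 4-cyanophenyl and 4-fluoro-3-methoxyphenyl differ at all in how much compound is left.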